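The compounds below may be only part of what the source reports. "The series", "measured", "known", "first", "only" and "open" are said of these compounds alone.

Measured in a functional assay on U-251 cells (Homo sapiens) for inhibition, read by sulforhodamine B assay, with a stated time of 48 h; on this read-out lower numbers stand for higher toxicity in this test and higher numbers for lower toxicity in this test:

compound 1 `CCOC(=O)[C@H](CCC(=O)O)NC(=O)c1ccc(CNc2nc3cc(N)cc(N)c3nc2-c2ccccc2)cc1` — a limit, < 100000 nM
compound 2 `Nc1cc(N)c2nc(-c3ccccc3)c(NCc3ccc(Cl)c(Cl)c3)nc2c1` — a limit, < 100000 nM
compound 3 `CCOC(=O)[C@H](CCC(=O)O)NC(=O)c1ccc(Sc2nc3cc(N)cc(N)c3nc2-c2ccccc2)cc1` — a limit, < 100000 nM

Compound 2 stands on a limit of this assay, not on a number. The same holds for compound 1 and for compound 3, so that the limit of < 100000 nM in this assay, at which 3 of the 3 values shown sit, is the whole of the evidence on this series in this assay. No step between measured compounds differing in one place is available, and nothing separates the three compounds from one another on the numbers shown.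

Compound 4 `Nc1cc(N)c2nc(-c3ccccc3)c(NCc3ccc(F)cc3)nc2c1` has not yet been measured in this assay. It differs from compound 2 by 4-fluorophenyl in place of 3,4-dichlorophenyl on a saturated chain carbon bound to a nitrogen on an aromatic ring. Among the compounds with values here, with every measured value sitting at the limit, no direction for the step is supported, and no change beyond the scatter is expected. Compound 4 is expected at 40000 nM in this assay, within 8000 nM to 100000 nM, which most likely means another limit rather than a number. The expected step that the limit leaves unreadable from compound 2 to compound 4 is, accordingly, an estimate of no change beyond the scatter.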

Compound 4, concentration lethal to 50% of the cells: 6310 nM
Estimate against measurement, compound 4: 6.3-fold (0.80 log units) above; measured number below the stated range.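

In this assay compound 2 gives only a limit, < 100000 nM. The step from compound 2 to compound 4 therefore cannot be read: the limit of < 100000 nM in this assay, at which 3 of the 4 values shown sit. From the compounds shown here alone, whether 4-fluorophenyl in place of 3,4-dichlorophenyl changes the read-out, and in which direction, stays open.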